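Swapping fluorine for chlorine on the benzyl ring

This account rests on a few compounds, and the source may have more. Where it says the series, first, only, none or still open, it means among the compounds named here.

Compound 2, `Cc1ccc(-c2nn(-c3ccccc3)cc2C(=O)NOCc2ccccc2F)cc1`, has the lowest number of the two measured compounds in a functional assay on A549 cells (Homo sapiens) for antiproliferative activity, read by MTT assay, with a stated time of 48 h, in the presence of a further agent that is not named here (a higher number here means a weaker inhibitor of growth, a lower number a stronger inhibitor of growth), giving 260 nM. Its nearest neighbour is compound 1, `Cc1ccc(-c2nn(-c3ccccc3)cc2C(=O)NOCc2ccccc2)cc1`, which in this assay gives 1140 nM; the step of a 4.4-fold lower number from compound 1 to compound 2 (0.64 log units; beyond the scatter) shows what placing a halogen on this ring did. Compound 3, `Cc1ccc(-c2nn(-c3ccccc3)cc2C(=O)NOCc2ccccc2Cl)cc1`, carries the change (chloro in place of fluoro on an aromatic carbon). For the measured compounds named here, only one measured step bears on it, the change from compound 1 to compound 2, and that step was modest though beyond the scatter. Exchanging one halogen for another at the same place is a smaller change than adding a halogen, so for compound 3 the number in this assay is expected to stay close to that of compound 2, with at most a small move in either direction, giving an expected step of a 1.3-fold lower number from compound 2 to compound 3 (0.11 log units; within the scatter). Compound 3 is therefore estimated at 200 nM, within a range from 70 nM to 600 nM.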

Compound 3, concentration for 50% growth inhibition: 380 nM
The estimate for compound 3 lay 1.9-fold (0.28 log units) below the measured number, and the stated range covers the measured number.
By their numbers in this assay, from the lowest: compounds 2 and 3 (each within the scatter of the next); then compound 1.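

With chloro in place of fluoro on this aromatic carbon, ortho to a large group, this assay gives a 1.5-fold higher number from compound 2 to compound 3 (0.16 log units; within the scatter), so the two halogens cannot be told apart at this place. Measured against the unsubstituted ring, chloro in place of hydrogen gives a 3.0-fold lower number from compound 1 to compound 3 (0.48 log units; beyond the scatter), which shows that the gain seen with fluoro is not unique to that one halogen and is shared by both halogens tested here. No measurement is available that would explain this result.

Going by these compounds, it remains open whether a non-halogen group, such as methyl, methoxy or trifluoromethyl, or the heavier halogen bromo, would do the same at this place. On these data alone, it is also open whether fluoro or chloro would give a similar step on another carbon of this ring.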